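The source may report more compounds than this note shows. Statements on the series, on what has been measured and on what is new or still open speak of the compounds shown alone.

Compound 1, `Clc1[nH]ccc2ncnc1-2`, gives in a functional assay on EL4 cells (Mus musculus) for inhibition, tested at 100 uM (a lower number here means less inhibition, a higher number more inhibition at the concentration tested (going by the name of the read-out)), only a limit of < 5%.
Compound 2, `OC[C@H]1O[C@@H](n2cnc3c(S)nccc32)C[C@@H]1O`, gives in this assay only a limit of < 5%.
Compound 3, `CSc1nccc2c1ncn2[C@H]1C[C@H](O)[C@@H](CO)O1`, gives in this assay only a limit of < 5%.

Compound 1 thus stands at the floor of this assay, and no number above that floor is known for it; the same holds for compound 2 and compound 3, as the limit of < 5% in this assay, at which 3 of the 3 values shown sit, records. The change to compound 4, `CSc1[nH]ccc2ncnc1-2`, is methylsulfanyl in place of chloro on an aromatic carbon. Among the measured compounds shown here, the one measured step that bears on this change is a step that the two limits leave unreadable from compound 2 to compound 3, which adds a methyl on a sulfur in a different setting and whose size cannot be read, both ends sitting at the limit. No direction or size can therefore be derived, and no step beyond the scatter is expected. Compound 4 is estimated at 3%, within 0% to 15%, a step that the limit leaves unreadable from compound 1 to compound 4.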

Compound 4, a percentage reported as inhibition, at one concentration (the size of the read-out at that concentration, not a potency): < 5%
Compound 4: only a limit was reported; the forecaster's own chance of this, stated with the estimate: 70%; the middle value does not contradict the limit.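

Compound 1 and compound 4 both give only a limit, so no step can be read between them: the limit of < 5% in this assay, at which 4 of the 4 values shown sit.
The compounds shown leave open whether chloro and methylsulfanyl differ at all in this assay, since none rises above this floor.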